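A few compounds are considered here, and "the series" means these few. Any claim that something is new, unique, unknown or untested is made for them only; others in the source may bear on it.

In a functional assay on blood (Platelet, Oryctolagus cuniculus) for inhibition, read by turbidimetry, with a stated time of 2 min (a higher number here means a weaker inhibitor, a lower number a stronger inhibitor), three compounds have been measured:

- compound 1 `CCOc1ccc(S(=O)(=O)N2CCN(c3ccccc3C)CC2)cc1S(=O)(=O)N1CCN(c2ccccc2C)CC1`: 650 nM
- compound 2 `CCOc1ccc(S(=O)(=O)N2CCN(c3cccc(C)c3)CC2)cc1S(=O)(=O)N1CCN(c2cccc(C)c2)CC1`: 430 nM
- compound 3 `COc1ccc(S(=O)(=O)N2CCN(c3ccc(C)cc3)CC2)cc1S(=O)(=O)N1CCN(c2ccc(C)cc2)CC1`: 680 nM

Compound 2 , at 430 nM, stands within the usual scatter of both compound 1 and compound 3 , so these numbers do not separate it from either. Compound 4 `COc1ccc(S(=O)(=O)N2CCN(c3cccc(C)c3)CC2)cc1S(=O)(=O)N1CCN(c2cccc(C)c2)CC1` has not yet been measured. It differs from compound 2 in one place: hydrogen in place of methyl on a saturated chain carbon bound to an oxygen on an aromatic ring. This is hydrogen in place of methyl on a saturated chain carbon bound to an oxygen on an aromatic ring, which turns ethoxy into methoxy. Within the data shown here, no two measured compounds differ in one place only, so the data give no direct measure of this change. In this assay, no step beyond the scatter is therefore expected, and no direction is favoured. The expected change is a 1.0-fold higher number from compound 2 to compound 4 (0.02 log units; within the scatter). This expectation starts from compound 2 at 430 nM, and the range is kept wide. The estimated value for compound 4 is 450 nM, with an expected range from 200 nM to 1000 nM.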

Compound 4, half-maximal inhibitory concentration: 710 nM
Compound 4: the middle estimate sits 1.6-fold (0.20 log units) below what was measured; the measured number falls inside the stated range.
By their numbers in this assay, from the lowest: compounds 2, 1, 3 and 4 (each within the scatter of the next).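

Among these compounds, the pair of compound 2 and compound 4 gives the first direct reading of this position, since ethoxy turns into methoxy while the rest of the structure stays the same. In this assay, putting hydrogen in place of methyl on the saturated chain carbon bound to an oxygen on an aromatic ring gives a 1.7-fold higher number from compound 2 to compound 4 (0.22 log units; within the scatter), so this change does not separate the two compounds. No measurement at hand bears on this result.

As far as these compounds go, whether a longer chain such as propoxy, or an amine or a carboxylic acid carried on that chain, would give a step beyond the scatter remains open. Also open, from the compounds shown here alone, is whether ethoxy to methoxy reads the same on the other structures, those of compound 1 and compound 3.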